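The compounds below may be only part of what the source reports. "The series", "measured", "known", "first", "only" and "open" are said of these compounds alone.

Compound 1, `O=C(CCCCCCc1ccccc1)c1ncc(Cl)o1`, in an assay on HEK-293T cells for inhibition of diacylglycerol lipase-alpha (Homo sapiens), read by colorimetric assay (on this read-out higher numbers stand for weaker inhibition and lower numbers for stronger inhibition), gives > 10000 nM, a limit of the assay and not a number.
Compound 2, `COc1cnc(C(=O)CCCCCCc2ccccc2)o1`, in this assay gives > 10000 nM, again a limit.
Compound 3, `O=C(CCCCCCc1ccccc1)c1ncc(-c2ccccc2F)o1`, in this assay gives > 10000 nM, again a limit.

Compound 3 therefore stands only as a limit, and nothing places it against the two others; (the limit of > 10000 nM in this assay, at which 3 of the 3 values shown sit). The steps that put the 2-fluorophenyl in place, a step that the two limits leave unreadable from compound 1 to compound 3 and a step that the two limits leave unreadable from compound 2 to compound 3, are unreadable, as is a step that the two limits leave unreadable from compound 1 to compound 2. Compound 4, `O=C(CCCCCCc1ccccc1)c1ncc(-c2ccc(F)cc2)o1`, differs from compound 3 in the fluorophenyl only: 4-fluorophenyl in place of 2-fluorophenyl on an aromatic carbon. Among the compounds with values here, no measured step moves a fluorine around this ring, and the steps that exchange the whole group give no readable size, so no direction in this assay follows from them. With every comparator at the limit, compound 4 is expected to give 15000 nM (range 4000 nM to 60000 nM), most likely again as a limit. The expected step, a step that the limit leaves unreadable from compound 3 to compound 4, is none beyond the scatter.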

Compound 4, half-maximal inhibitory concentration: > 10000 nM
Compound 4: only a limit was reported (the forecaster's own chance of this, stated with the estimate: 80%); the middle value does not contradict the limit.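

Compound 4 is also only a limit, so no step from compound 1, compound 2 or compound 3 to compound 4 can be read: the limit of > 10000 nM in this assay, at which 4 of the 4 values shown sit.

Which group on the shared core, if any, gives a measurable value in this assay stays open.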